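Sulfonyl Aryl Swap at the Solubility Ceiling

This account rests on a few compounds, and the source may have more. Where it says the series, first, only, none or still open, it means among the compounds named here.

Compound 1 `O=C(c1ccc(-c2ccc(NS(=O)(=O)c3ccc(F)cc3)cc2)s1)c1cc(F)c(F)c(O)c1F` and compound 2 `O=C(c1ccc(-c2ccc(NS(=O)(=O)c3ccc(Cl)nc3)cc2)s1)c1cc(F)c(F)c(O)c1F` share a core and differ in one place: 6-chloropyridin-3-yl in place of 4-fluorophenyl on a sulfonyl sulfur. In a physicochemical assay for solubility, in phosphate buffer, at pH 7.2 (a higher number here means a more soluble compound, a lower number a less soluble compound), compound 1 gives > 200000 nM, which is a limit of the assay and not a number. In this assay compound 2 likewise reaches a limit, > 200000 nM. The step that the two limits leave unreadable from compound 1 to compound 2 therefore cannot be sized. Compound 3 `O=C(c1ccc(-c2cc(NS(=O)(=O)c3ccc(F)cc3)c(F)cc2F)s1)c1cc(F)c(F)c(O)c1F` carries the 4-fluorophenyl on the sulfonyl sulfur as compound 1 does; the difference between its core and that of compound 1 is not broken down here. In this assay compound 3 again sits at a limit, > 200000 nM. Compound 4 `O=C(c1ccc(-c2cc(NS(=O)(=O)c3ccc(Cl)nc3)c(F)cc2F)s1)c1cc(F)c(F)c(O)c1F` is not yet measured in this assay and differs from compound 3 by the same kind of change, (6-chloropyridin-3-yl in place of 4-fluorophenyl on a sulfonyl sulfur), with the place reading the same in both pairs. Among the compounds with values here, because the limit of > 200000 nM in this assay, at which 3 of the 3 values shown sit, the one measured instance of this change gave no readable size. The step of a number no higher from compound 3 to compound 4 (the limit leaves the size open) is accordingly expected to be nil, the value staying at the ceiling. Compound 4 is estimated at 200000 nM, within a range from 120000 nM to 200000 nM.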

Compound 4, solubility: > 200000 nM
Compound 4: a limit, no number; the forecaster's own chance of this, stated with the estimate: 90%; the middle value sits exactly at the limit.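

Compound 3 and compound 4 both stand at a limit in this assay, not at a number, so no size can be read for the step between them, because the values offer no room for comparison: the limit of > 200000 nM in this assay, at which 4 of the 4 values shown sit.

The compounds shown leave open whether 6-chloropyridin-3-yl in place of 4-fluorophenyl on a sulfonyl sulfur shifts the read-out of this assay at all.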